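Removing one methoxy group from compound 2

A few compounds are considered here, and "the series" means these few. Any claim that something is new, unique, unknown or untested is made for them only; others in the source may bear on it.

Measured compounds:
compound 1 `COc1ccc(-c2cc(/C=C/C(=O)c3ccc(N)cc3)[nH]n2)cc1`: 12%
compound 2 `COc1cc(-c2cc(/C=C/C(=O)c3ccc(N)cc3)[nH]n2)cc(OC)c1OC`: 26%
compound 3 `COc1ccc(C(=O)/C=C/c2cc(-c3cc(OC)c(OC)c(OC)c3)n[nH]2)cc1`: -29%

Three compounds share a core and were tested in a functional assay on TK-10 cells (Homo sapiens) for cytotoxicity, read by sulforhodamine B assay, with a stated time of 48 h, tested at 10 uM; a higher number here means a weaker effect of the compound at the concentration tested, a lower number a stronger effect. Compound 1 `COc1ccc(-c2cc(/C=C/C(=O)c3ccc(N)cc3)[nH]n2)cc1` gives 12%, compound 2 `COc1cc(-c2cc(/C=C/C(=O)c3ccc(N)cc3)[nH]n2)cc(OC)c1OC` gives 26%, and compound 3 `COc1ccc(C(=O)/C=C/c2cc(-c3cc(OC)c(OC)c(OC)c3)n[nH]2)cc1` gives -29%. Compound 2 stands highest of the three: compound 1 lies nearest, beyond the scatter, and compound 3 lies furthest. Among the measured compounds shown here, the only step between compounds differing in one place is a number 55 percentage points lower from compound 2 to compound 3 (beyond the scatter), a large change that concerns the amino group, not the methoxy groups.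

Compound 4 `COc1ccc(-c2cc(/C=C/C(=O)c3ccc(N)cc3)[nH]n2)cc1OC` differs from compound 2 in this way: hydrogen in place of methoxy on an aromatic carbon. For the measured compounds named here, no measured step covers removal of a methoxy group, so the expectation rests on what the values of compound 1 and compound 2 show, as compound 4 carries a methoxy count between them. Compound 4 is therefore expected to give 18%, within 0% to 35%, a step of a number 8 percentage points lower from compound 2 to compound 4 (within the scatter) expected to be modest.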

Compound 4, a percentage reported as activity, at one concentration (the size of the read-out at that concentration, not a potency): 56%
Estimate against measurement, compound 4: 38 percentage points below; the whole stated range lies below it.
By their numbers in this assay, from the lowest: compound 3; then compound 1; then compound 2; then compound 4.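

Replacing this methoxy group, ortho to a methoxy group and meta to a large group, with hydrogen is not a neutral change in this assay: it gives a number 30 percentage points higher from compound 2 to compound 4 (beyond the scatter), a weaker effect at the concentration tested. Methoxy in place of hydrogen on an aromatic carbon gives a number 44 percentage points higher from compound 1 to compound 4 (beyond the scatter), so both steps reach a weaker effect at compound 4, and the read-out does not follow the number of methoxy groups across these three compounds. Nothing available explains why the compound with the intermediate methoxy count stands above both neighbours.

From the compounds shown here alone, it remains open whether a hydroxy group or a chlorine atom at this carbon would behave as hydrogen does or as methoxy does. Also open, going by these compounds, is whether methoxy in place of amino on the shared core of compound 4 would give a step like a number 55 percentage points lower from compound 2 to compound 3 (beyond the scatter).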